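Adding a 2-methylphenyl group to compound 2

The source may report more compounds than this note shows. Statements on the series, on what has been measured and on what is new or still open speak of the compounds shown alone.

Of the compounds shown here, two have been measured so far, compound 1 `Nc1ncn(Cc2c(Cl)cccc2Cl)c2ncnc1-2` and compound 2 `Nc1ncn(Cc2c(Cl)cncc2Cl)c2ncnc1-2`. In an ADME assay on the whole organism (Mus musculus, strain C57BL/6) for pharmacokinetics, read by LC-MS, with a stated time of 24 h, at a dose of 10 mg/kg by the oral route (a higher number here means more compound in the circulation at the dose given, a lower number less compound in the circulation), compound 1 gives 18500 ng.h/mL and compound 2 gives 9500 ng.h/mL. These two values lie within the usual scatter of each other, so compound 2 stands level with compound 1 on the numbers available.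

Compound 3 `Cc1ccccc1-c1nc2c(N)ncn(Cc3c(Cl)cncc3Cl)c-2n1` carries one structural change from compound 2: 2-methylphenyl in place of hydrogen on an aromatic carbon, with 2-methylphenyl in place of hydrogen on an aromatic carbon. Going by the values given here, no measured pair shows what such a change does in this assay, so any expectation here is a loose one. A moderate fall, just beyond the scatter, seems the likeliest outcome, though a result within the scatter remains possible. The expected move is a 2.1-fold lower number from compound 2 to compound 3 (0.32 log units; beyond the scatter). For compound 3 the estimate is 4500 ng.h/mL, with an expected range from 1200 ng.h/mL to 16000 ng.h/mL.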

Compound 3, area under the concentration-time curve: 38 ng.h/mL
Estimate against measurement, compound 3: 120-fold (2.07 log units) above; measured number below the stated range.
By their numbers in this assay, from the lowest: compound 3; then compounds 2 and 1 (each within the scatter of the next).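

In this assay, going by these compounds alone, the earlier compounds carry only hydrogen on the aromatic carbon between two ring nitrogen atoms, so they gave no sign of how much this place matters. Putting 2-methylphenyl there brings a 250-fold lower number from compound 2 to compound 3 (2.40 log units; beyond the scatter), a large step well beyond the scatter, which shows that a single change at this carbon can strongly reduce the amount of compound in the circulation. Nothing available explains why the number falls this far.

The compounds shown leave open whether a smaller group at this carbon, such as a single methyl or an amine, or a plain phenyl ring without its methyl, would keep the number closer to that of compound 2. They also leave open whether 2-methylphenyl would have the same effect on compound 1.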